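Methyl on the amide nitrogen: compound 1 to compound 4

This account rests on a few compounds, and the source may have more. Where it says the series, first, only, none or still open, it means among the compounds named here.

Compound 1 `CNC(=O)/C=C/c1ccncc1-c1ccc2ccccc2c1` is the parent of this pair. In a functional assay on MCF7 cells (Homo sapiens) for inhibition, read by sulforhodamine B assay, with a stated time of 72 h (on this read-out lower numbers stand for stronger inhibition of growth and higher numbers for weaker inhibition of growth), compound 1 gives 9340 nM, the highest of the two numbers recorded in this assay; the nearest is compound 2 `CCOC(=O)/C=C/c1ccncc1-c1ccc2cc[nH]c2c1`, which gives 6880 nM, and the gap between the two lies within the scatter, so no order between them is claimed. Compound 3 `O=C(/C=C/c1ccncc1-c1ccc2cc[nH]c2c1)N1CCOCC1` carries a morpholin-4-yl in place of the ethoxy of compound 2 on the carbonyl carbon. For compound 3 this assay reports only a limit, > 10000 nM. Within the data shown here, the single step with a direction attached, an at least 1.4-fold higher number from compound 2 to compound 3 (0.16 log units; that floor lies within the scatter), therefore sets no more than a floor, and that floor sits within the scatter; the evidence behind it is the limit of > 10000 nM in this assay, at which 1 of the 3 values shown sits.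

Compound 4 `CN(C)C(=O)/C=C/c1ccncc1-c1ccc2ccccc2c1` differs from compound 1 by methyl in place of hydrogen on an amide-type nitrogen. Among the measured compounds shown here, no measured step touches the substitution on the amide-type nitrogen, and the one step that alters the group on the carbonyl carbon moved the number at most modestly. In this assay no movement beyond the scatter is expected for compound 4, an estimated step of a 1.2-fold higher number from compound 1 to compound 4 (0.07 log units; within the scatter). Compound 4 is thus expected to give about 11000 nM in this assay, with a range from 4500 nM to 27000 nM, and since that sits near the limit of the assay there is a fair chance that only a limit is reported.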

Compound 4, concentration for 50% growth inhibition: 8190 nM
Compound 4: middle estimate off by 1.3-fold (0.13 log units), on the high side; the measured number falls inside the stated range.
By their numbers in this assay, from the lowest: compounds 2, 4 and 1 (each within the scatter of the next). At a limit, above all of these: compound 3.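

In this assay, among these compounds, the one step that alters the substitution on this amide-type nitrogen reads a 1.1-fold lower number from compound 1 to compound 4 (0.06 log units; within the scatter). Methylcarbamoyl and dimethylcarbamoyl are therefore not told apart by this read-out, and the amide hydrogen can give way to methyl with no movement beyond the scatter; this rests on a single pair and makes no claim for any other group at this nitrogen. Compound 3 is still reported only as a limit, so the upper end of the read-out continues to restrict what can be seen in this series: the limit of > 10000 nM in this assay, at which 1 of the 4 values shown sits.

As far as these compounds go, it remains open whether a larger group on this nitrogen, such as an ethyl, a benzyl or a chain ending in an amine, or a carboxylic acid in place of the amide, would bring a step beyond the scatter in this assay. It is equally open whether methyl in place of hydrogen on an amide-type nitrogen would read the same on the core of compound 2, since the pair shown here carries the core of compound 1.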